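Trifluoromethyl placement on the aryl group in compound 4

The source may report more compounds than this note shows. Statements on the series, on what has been measured and on what is new or still open speak of the compounds shown alone.

In an assay on HEK293 cells for inhibition of Voltage-dependent T-type calcium channel subunit alpha-1G (Homo sapiens), read by fluorescence, tested at 10 uM (a lower number here means less inhibition, a higher number more inhibition at the concentration tested (going by the name of the read-out)), compound 1 `CCCc1nc(-c2ccccc2)c(CNCCCN2CCN(c3ccc(F)cc3)CC2)o1` gives 62.5%. Compound 2 `CCCc1nc(-c2ccccc2)c(CNCCCN2CCN(c3cccc(C(F)(F)F)c3)CC2)o1` gives 51.6% in this assay, and compound 3 `CCCc1nc(-c2ccccc2)c(CNCCCN2CCN(c3ccc(C(F)(F)F)cc3)CC2)o1` gives 51.6%. Compound 3 stands level with compound 2 at the digits shown, and together the two make the lowest pair of the three numbers; compound 1 is the furthest away, as a number 10.9 percentage points lower from compound 1 to compound 3 (beyond the scatter) records. The change to compound 4 `CCCc1nc(-c2ccccc2)c(CNCCCN2CCN(c3ccccc3C(F)(F)F)CC2)o1` is 2-(trifluoromethyl)phenyl in place of 4-(trifluoromethyl)phenyl on an amine nitrogen in a ring. The step that bears most directly on it is no change at the digits printed from compound 2 to compound 3 (within the scatter), where the trifluoromethyl group was likewise shifted around the aryl ring with no change beyond the scatter. The steps of a number 10.9 percentage points lower from compound 1 to compound 2 (beyond the scatter) and a number 10.9 percentage points lower from compound 1 to compound 3 (beyond the scatter) concern the swap of fluoro for trifluoromethyl, which is not part of the present change, since here the trifluoromethyl group is kept and only its place on the ring moves. Compound 4 is therefore expected to give about 50% in this assay, with a range of 38% to 62%. The step of a number 1.6 percentage points lower from compound 3 to compound 4 (within the scatter) that this estimate means is expected to be none beyond the scatter.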

Compound 4, a percentage reported as inhibition, at one concentration (the size of the read-out at that concentration, not a potency): 45%
Estimate against measurement, compound 4: 5 percentage points above; the measured number falls inside the stated range.
By their numbers in this assay, from the lowest: compounds 4, 2 and 3 (each within the scatter of the next); then compound 1.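

In this assay, the 2-(trifluoromethyl)phenyl group extends the placement comparison to a third isomer, and the results show a number 6.6 percentage points lower from compound 3 to compound 4 (within the scatter) and a number 6.6 percentage points lower from compound 2 to compound 4 (within the scatter). Placement of the trifluoromethyl group on this aryl ring therefore separates none of the three isomers beyond the scatter in this assay. The 4-fluorophenyl comparison also holds for the new isomer, with a number 17.5 percentage points lower from compound 1 to compound 4 (beyond the scatter), so compound 1 stands apart from compound 2, compound 3 and compound 4.

No supporting data bear on the reason for this flat placement result or for the separation of compound 1. On these data alone, it remains open whether a methoxy group or a nitrile in place of trifluoromethyl on the aryl ring would read like the trifluoromethyl isomers or like compound 1 in this assay.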